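Swapping in 4-chlorophenyl: the step from compound 3

The source may report more compounds than this note shows. Statements on the series, on what has been measured and on what is new or still open speak of the compounds shown alone.

Measured in a functional assay on NCI-H460 cells (Homo sapiens) for inhibition, read by MTT assay, with a stated time of 72 h; on this read-out higher numbers stand for weaker inhibition and lower numbers for stronger inhibition:
- compound 1 `COc1cc(NC(C)CCCNC(=O)Nc2ccc(F)cc2)c2ncccc2c1` gives 26000 nM
- compound 2 `COc1cc(NC(C)CCCNC(=O)NNC(=O)Nc2cccc(F)c2)c2ncccc2c1` gives 50000 nM
- compound 3 `COc1cc(NC(C)CCCNC(=O)Nc2cccc(C(F)(F)F)c2)c2ncccc2c1` gives 21000 nM

Compound 3 sits level with one measured neighbour and modestly under the other (a 1.2-fold lower number from compound 1 to compound 3 (0.09 log units; within the scatter) and a 2.4-fold lower number from compound 2 to compound 3 (0.38 log units; beyond the scatter)). Compound 4 `COc1cc(NC(C)CCCNC(=O)Nc2ccc(Cl)cc2)c2ncccc2c1` carries 4-chlorophenyl in place of 3-(trifluoromethyl)phenyl on an amide-type nitrogen. For the measured compounds named here, the one measured exchange of one substituted phenyl for another (a 1.2-fold lower number from compound 1 to compound 3 (0.09 log units; within the scatter)) stayed within the scatter. The larger step (a 2.4-fold lower number from compound 2 to compound 3 (0.38 log units; beyond the scatter)) involves the ((3-fluorophenyl)carbamoyl)amino group, which plays no part here. No step beyond the scatter is therefore expected in this assay. The expected step is a 1.0-fold higher number from compound 3 to compound 4 (0.02 log units; within the scatter). Compound 4 is estimated at 22000 nM, with an expected range of 11000 nM to 45000 nM.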

Compound 4, half-maximal inhibitory concentration: 34000 nM
Compound 4: middle estimate off by 1.5-fold (0.19 log units), on the low side; the measured number falls inside the stated range.
By their numbers in this assay, from the lowest: compounds 3, 1, 4 and 2 (each within the scatter of the next, the first and the last beyond it).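

In this assay, a third substituted phenyl on the amide-type nitrogen again gives no step beyond the scatter (a 1.6-fold higher number from compound 3 to compound 4 (0.21 log units; within the scatter)), and chloro in place of fluoro on an aromatic carbon behaves alike (a 1.3-fold higher number from compound 1 to compound 4 (0.12 log units; within the scatter)). The ((3-fluorophenyl)carbamoyl)amino group is also not separated from 4-chlorophenyl (a 1.5-fold lower number from compound 2 to compound 4 (0.17 log units; within the scatter)), so only compound 3 stands apart from compound 2. No evidence on the cause of these numbers is available. Still open, from the compounds shown here alone, is whether a phenyl carrying an amine or a carboxylic acid would move the number beyond the scatter.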